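Swapping phenyl for furan-2-yl on a shared core

This account rests on a few compounds, and the source may have more. Where it says the series, first, only, none or still open, it means among the compounds named here.

In a functional assay on MDA-MB-231 cells (Homo sapiens) for cytotoxicity, read by ELISA, with a stated time of 2 days (on this read-out lower numbers stand for stronger inhibition and higher numbers for weaker inhibition), compound 3 (`Oc1cccc(-c2cc(-c3ccccc3)nc(-c3ccccc3)c2)c1`) gives 19500 nM. That value lies within the usual scatter of both neighbours: compound 1 (`Oc1cccc(-c2cc(-c3ccccc3)cc(-c3ccco3)n2)c1`) at 13700 nM and compound 2 (`Oc1cccc(-c2cc(-c3ccccc3)cc(-c3ccncc3)n2)c1`) at 10400 nM. The three therefore cannot be ranked.

Compound 4 (`Oc1cccc(-c2cc(-c3ccccc3)nc(-c3ccco3)c2)c1`) differs from compound 3 in one place, with furan-2-yl in place of phenyl on an aromatic carbon.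

No exchange of phenyl for furan-2-yl has been measured, so the evidence is indirect. Going by the values given here, the only measured single change is a 1.3-fold lower number from compound 1 to compound 2 (0.12 log units; within the scatter), where pyridin-4-yl replaces furan-2-yl, and it stays within the scatter. Compound 1, which also carries furan-2-yl, gives 13700 nM, within the scatter of compound 3. On this evidence, no step beyond the scatter is expected in this assay.

The estimated change is a 1.3-fold lower number from compound 3 to compound 4 (0.11 log units; within the scatter), with no clear direction. Compound 4 is expected at about 15000 nM, within an estimated range of 7500 nM to 30000 nM.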

Compound 4, half-maximal inhibitory concentration: 20800 nM
The estimate for compound 4 lay 1.4-fold (0.14 log units) below the measured number, within the range that was stated.
By their numbers in this assay, from the lowest: compounds 2, 1, 3 and 4 (each within the scatter of the next).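

In this assay, this is the one direct exchange of phenyl for furan-2-yl shown, on an aromatic carbon next to the ring nitrogen, and it gives a 1.1-fold higher number from compound 3 to compound 4 (0.03 log units; within the scatter). At this position, then, replacing a six-membered carbon ring with a five-membered ring that carries one oxygen and one hydrogen-bond acceptor produces no change that can be told from the scatter of repeated measurements. No measured evidence is available to explain this outcome.

The compounds shown leave open whether a different kind of group at this position, such as an amine, a carboxylic acid or a longer alkyl chain, would move the number beyond the scatter. They also leave open whether this exchange would behave the same way on another core.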